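This account rests on a few compounds, and the source may have more. Where it says the series, first, only, none or still open, it means among the compounds named here.

Measured compounds:
- compound 1, `CCOC(=O)[C@@H](F)ON1C(=O)N2C[C@H]1C=C(C)[C@H]2C(N)=O`: 45%
- compound 2, `CC1=C[C@@H]2CN(C(=O)N2O[C@H](F)C(=O)OC(C)C)[C@@H]1C(N)=O`: 38%
- compound 3, `CCOC(=O)[C@H](F)ON1C(=O)N2C[C@H]1C(C)=C[C@H]2C(N)=O`: 71%

In an ADME assay on the whole organism (Rattus norvegicus, strain Sprague-Dawley) for pharmacokinetics, read by LC-MS, at a dose of 10 mg/kg by the oral route (on this read-out lower numbers stand for lower oral bioavailability and higher numbers for higher oral bioavailability), compound 1 gives 45%. Compound 2 gives 38%. Compound 3 gives 71%, the highest of the three numbers. Compound 2 carries methyl in place of hydrogen on a saturated chain carbon bound to an oxygen next to a carbonyl group and a saturated chain carbon, and this change gave a number 7 percentage points lower from compound 1 to compound 2 (within the scatter). Compound 3 has the same atoms as compound 1 joined differently; the difference between the two cores is not broken down here. Compound 4, `CC1=C[C@@H](C(N)=O)N2C[C@@H]1N(O[C@@H](F)C(=O)OC(C)C)C2=O`, is not yet measured in this assay. It is to compound 3 what compound 2 is to compound 1, namely (methyl in place of hydrogen on a saturated chain carbon bound to an oxygen next to a carbonyl group and a saturated chain carbon), at a place described in the same words. Among the compounds with values here, the step is expected to be a number 7 percentage points lower from compound 3 to compound 4 (within the scatter), resting on the single earlier instance, a number 7 percentage points lower from compound 1 to compound 2 (within the scatter), which is the only guide, since a second core may respond otherwise. Compound 4 is therefore estimated at 64%, expected between 46% and 80%.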

Compound 4, oral bioavailability: 84%
Beside the measured number, compound 4's estimate is 20 percentage points below it; measured number outside the range, above it.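

The change from ethoxycarbonyl to isopropoxycarbonyl, read in this assay, gives a number 13 percentage points higher from compound 3 to compound 4 (beyond the scatter). The same change does not carry over as a fixed increment between these cores: the same change on two cores in this assay, a number 7 percentage points lower (within the scatter) from compound 1 to compound 2 and a number 13 percentage points higher (beyond the scatter) from compound 3 to compound 4, 20 percentage points apart, beyond the scatter of two such steps This shows that, for these two pairs, the step read on one core does not predict the step on the other, but it does not explain the difference or establish a rule for other cores.

The compounds shown leave open how n-butoxycarbonyl, with its longer chain, or a carboxylic acid in place of the ester would read on either core. They also leave open whether any further ester would follow the step seen on the core of compound 1 or that seen on the core of compound 3.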